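The source may report more compounds than this note shows. Statements on the series, on what has been measured and on what is new or still open speak of the compounds shown alone.

Measured so far in an ADME assay on microsomes from liver (Mus musculus) for metabolic stability, read by HPLC, using NADPH, with a stated time of 60 min, tested at 1 uM, in the presence of a further agent that is not named here; a lower number here means slower removal, a higher number faster removal of the compound:
Compound 1 `Cc1cc(-c2ncccn2)cc(C(=O)NNS(=O)(=O)c2ccccc2)c1F` gives 279 uL/min in this assay.
Compound 2 `Cc1cc(-n2cccn2)cc(C(=O)NNS(=O)(=O)c2ccccc2)c1F` gives 567 uL/min in this assay.
Compound 3 `Cc1cc(-c2ccccn2)cc(C(=O)NNS(=O)(=O)c2ccccc2)c1F` gives 424 uL/min in this assay.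

Compound 3 holds the second highest of the three numbers, but its gaps to the others, a 1.3-fold lower number from compound 2 to compound 3 (0.13 log units; within the scatter) and a 1.5-fold higher number from compound 1 to compound 3 (0.18 log units; within the scatter), both lie within the scatter, so no order among the three can be stated. Compound 4 `Cc1cc(-n2nccn2)cc(C(=O)NNS(=O)(=O)c2ccccc2)c1F` differs from compound 3 by 2H-1,2,3-triazol-2-yl in place of pyridin-2-yl on an aromatic carbon. For the measured compounds named here, the steps that bear on this are a 2.0-fold higher number from compound 1 to compound 2 (0.31 log units; beyond the scatter), where 1H-pyrazol-1-yl enters and which is modest yet beyond the scatter, and a 1.3-fold lower number from compound 2 to compound 3 (0.13 log units; within the scatter), where 1H-pyrazol-1-yl leaves for pyridin-2-yl and which stays within it. Reversing the latter suggests at most a small rise in this assay, expected as a 1.2-fold higher number from compound 3 to compound 4 (0.07 log units; within the scatter), not beyond the scatter. Compound 4 is estimated at 500 uL/min, with a range from 280 uL/min to 900 uL/min.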

Compound 4, intrinsic clearance in a liver preparation (reported as CLH), per the amount of preparation that the assay uses: 865 uL/min
Compound 4: middle estimate off by 1.7-fold (0.24 log units), on the low side; measured number inside the range.
By their numbers in this assay, from the lowest: compounds 1, 3, 2 and 4 (each within the scatter of the next, the first and the last beyond it).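

In this assay 2H-1,2,3-triazol-2-yl is the first group at this position to stand beyond the scatter from pyridin-2-yl (a 2.0-fold higher number from compound 3 to compound 4 (0.31 log units; beyond the scatter)), and its step from pyrimidin-2-yl (a 3.1-fold higher number from compound 1 to compound 4 (0.49 log units; beyond the scatter)) is the largest shown here. Against 1H-pyrazol-1-yl it stays within the scatter (a 1.5-fold higher number from compound 2 to compound 4 (0.18 log units; within the scatter)), so these two groups cannot be ordered. Nothing at hand gives a cause for these steps.

Open, from the compounds shown here alone, is how an amine, a carboxylic acid or a simple methoxy group at this position would read. Also open, going by these compounds, is whether these steps would hold with the shared core changed elsewhere.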